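Furan in Place of Thiophene: an Expected Cytotoxicity Outcome

The compounds below may be only part of what the source reports. "The series", "measured", "known", "first", "only" and "open" are said of these compounds alone.

Compound 1 `Oc1cccc(-c2cc(-c3ccsc3)cc(-c3ccccc3O)n2)c1`: in a functional assay on HCT-15 cells (Homo sapiens) for cytotoxicity, read by CCK-8 assay (a lower number here means a stronger inhibitor, a higher number a weaker inhibitor), compound 1 gives only a limit of the assay, > 50000 nM.
Compound 2 `Oc1ccc(-c2cc(-c3ccsc3)cc(-c3ccccc3O)n2)cc1`: in this assay compound 2 also gives only a limit of the assay, > 50000 nM.
Compound 3 `Oc1ccc(-c2cc(-c3ccsc3)cc(-c3cccc(O)c3)n2)cc1`: in this assay compound 3 gives a measured number, 1180 nM.

For the measured compounds named here, compound 2 thus stands at the limit, together with compound 1 (the limit of > 50000 nM in this assay, at which 2 of the 3 values shown sit), while compound 3 is the only one with a readable value. The measured steps all move a hydroxyl group around a phenyl: an at least 42-fold lower number from compound 1 to compound 3 (1.62 log units; beyond the scatter) and an at least 42-fold lower number from compound 2 to compound 3 (1.62 log units; beyond the scatter) are large, whereas a step that the two limits leave unreadable from compound 1 to compound 2.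

Compound 4 `Oc1ccc(-c2cc(-c3ccoc3)cc(-c3ccccc3O)n2)cc1` differs from compound 2 in another place entirely: furan-3-yl in place of thiophen-3-yl on an aromatic carbon. Going by the values given here, no measured step touches this group, so none bears directly on the change. With compound 2 already at the limit, compound 4 is expected to stay at or near it, with a step that the limit leaves unreadable from compound 2 to compound 4 expected to be small. The estimate for compound 4 in this assay is 60000 nM, within 10000 nM to 300000 nM.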

Compound 4, half-maximal inhibitory concentration: > 50000 nM
Compound 4 ended at the assay's limit; the forecaster's own chance of this, stated with the estimate: 75%; the middle value does not contradict the limit.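

Compound 2 and compound 4 both end at a limit of the assay rather than at a number, so swapping thiophen-3-yl for furan-3-yl gives no readable step: the limit of > 50000 nM in this assay, at which 3 of the 4 values shown sit.

The compounds shown leave open whether these two groups differ at all in this assay.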